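Removing One Fluoro from the Difluorophenyl Amide of Compound 1

The compounds below may be only part of what the source reports. "The series", "measured", "known", "first", "only" and "open" are said of these compounds alone.

Two measured compounds share a core built around a trifluoromethyl-bearing thiazole carrying an acylurea on one side and an acylhydrazone on the other. Compound 1 `CN(C(=O)NC(=O)c1c(F)cccc1F)c1nc(C(F)(F)F)c(C(=O)N/N=C/c2cccc(C(F)(F)F)c2)s1` gives 21.6 ug/mL in a functional assay on HeLa cells (Homo sapiens) for inhibition, read by MTT assay, with a stated time of 72 h; on this read-out higher numbers stand for weaker inhibition and lower numbers for stronger inhibition; compound 2 `CN(C(=O)NC(=O)c1c(F)cccc1F)c1nc(C(F)(F)F)c(C(=O)N/N=C/c2ccccc2C(F)(F)F)s1` gives 19.6 ug/mL in the same assay. The one measured step, a 1.1-fold lower number from compound 1 to compound 2 (0.04 log units; within the scatter), moves the trifluoromethyl around the hydrazone phenyl and lies within the scatter, so on the numbers shown compound 1 stands as the highest of the two, with compound 2 beside it at a distance that means nothing.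

Compound 3 `CN(C(=O)NC(=O)c1ccccc1F)c1nc(C(F)(F)F)c(C(=O)N/N=C/c2cccc(C(F)(F)F)c2)s1` differs from compound 1 at the other end of the molecule: hydrogen in place of fluoro on an aromatic carbon, that is, 2,6-difluorophenyl becomes 2-fluorophenyl on the acyl part of the acylurea. Going by the values given here, no measured step touches this amide, so the only evidence is that a small change elsewhere left this assay unmoved. With nothing pointing in either direction, the expected step of a 1.0-fold higher number from compound 1 to compound 3 (0.01 log units; within the scatter) is none beyond the scatter. Compound 3 is therefore estimated at 22 ug/mL, within a range from 10 ug/mL to 48 ug/mL.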

Compound 3, half-maximal inhibitory concentration: 19.1 ug/mL
Compound 3: the middle estimate sits 1.2-fold (0.06 log units) above what was measured, within the range that was stated.
By their numbers in this assay, from the lowest: compounds 3, 2 and 1 (each within the scatter of the next).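

Replacing one fluoro with hydrogen, so that 2,6-difluorophenyl becomes 2-fluorophenyl on the acyl part of the acylurea, gives a 1.1-fold lower number from compound 1 to compound 3 (0.05 log units; within the scatter) in this assay. This is the first measured step at this end of the molecule, and on these numbers compound 1 and compound 3 cannot be told apart, so the second fluoro on this ring is not shown to matter for the read-out. No measurement at hand offers an explanation for this result.

The compounds shown leave open whether the remaining fluoro could also give way to hydrogen, and whether a larger group on this ring, such as a methoxy or an amine, would produce a step beyond the scatter. They also leave open how the 2-fluorophenyl amide of compound 3 would behave alongside the 2-(trifluoromethyl)phenyl of compound 2, since the two changes appear only separately, each in its own compound.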